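Clearance notes on the shared core: compound 2 to compound 3

The source may hold more compounds than are shown below. What is called first, only, known or untested is meant among the compounds shown, and "the series" means these compounds.

Measured in an in vivo ADME assay on the whole organism for pharmacokinetics, with Rattus norvegicus as the target, at a dose of 5 mg/kg by the intravenous route; a higher number here means faster removal of the compound, a lower number slower removal:
- compound 1 `COc1ccc(C(CC(=O)O)Cc2nc(CCCc3ccc4c(n3)NCCC4)no2)cn1`: 12 mL/min/kg
- compound 2 `O=C(O)CC(Cc1nc(CCCc2ccc3c(n2)NCCC3)no1)c1cnc(C2CC2)s1`: 5.56 mL/min/kg

Among the compounds with values here, compound 2 holds the lowest of the two numbers; the one measured step on this series, a 2.2-fold lower number from compound 1 to compound 2 (0.33 log units; beyond the scatter), is an exchange of one aromatic group for another on the saturated chain carbon bound to two saturated chain carbons.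

Compound 3 `O=C(O)CC(Cc1nc(CCCc2ccc3c(n2)NCCC3)no1)c1ccc2c(c1)OCC2` changes that same position: a group of 9 heavy atoms (8 carbon, 1 oxygen; one five-membered non-aromatic ring with 1 hetero atom, one six-membered aromatic ring of carbon only) in place of a group of 8 heavy atoms (6 carbon, 1 nitrogen, 1 sulfur; one three-membered non-aromatic ring of carbon only, one five-membered aromatic ring with 2 hetero atoms), on a saturated chain carbon bound to two saturated chain carbons. Within the data shown here, no measured step matches this exchange, so the only guide is that a group swap at this position has so far moved this assay by a modest amount, beyond the scatter but not far. A step of similar size is expected, more likely upward than downward since compound 2 is the lower of the two values and compound 1 gives 12 mL/min/kg.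

For compound 3 the clearance in this assay is estimated at 8.5 mL/min/kg, with a range of 4 mL/min/kg to 18 mL/min/kg. The expected step from this estimate is a 1.5-fold higher number from compound 2 to compound 3 (0.18 log units; within the scatter).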

Compound 3, clearance: 17.3 mL/min/kg
For compound 3 the middle estimate is 2.0-fold (0.31 log units) below the measured one, within the range that was stated.
By their numbers in this assay, from the lowest: compound 2; then compounds 1 and 3 (each within the scatter of the next).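

Compound 2, with its 2-cyclopropyl-1,3-thiazol-5-yl group, now stands alone at the low end of this assay and the exchange for the new group gives a 3.1-fold higher number from compound 2 to compound 3 (0.49 log units; beyond the scatter) in this series. The 6-methoxypyridin-3-yl group and the new group cannot be told apart at this position, with a 1.4-fold higher number from compound 1 to compound 3 (0.16 log units; within the scatter) as the step between them, so among these three compounds only the 2-cyclopropyl-1,3-thiazol-5-yl group separates from the others. Nothing at hand explains this separation.

Still open, from the compounds shown here alone, is whether the lower number goes with the cyclopropyl group or with the five-membered aromatic ring that carries it. A 2-methyl-1,3-thiazol-5-yl group or a plain phenyl group on the same saturated chain carbon would speak to that question.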